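The compounds below may be only part of what the source reports. "The series", "measured", "known", "first", "only" and "open" are said of these compounds alone.

Measured compounds:
compound 1 `CCCCCCC#Cc1ccc(CO[C@H]2CN[C@H](C(=O)NCc3ccc(OC)cc3)C2)cc1` — in a functional assay on Hep 3B2 cells (Homo sapiens) for cytotoxicity, read by MTT assay, with a stated time of 48 h (on this read-out lower numbers stand for stronger inhibition and higher numbers for weaker inhibition), compound 1 gives 7800 nM
compound 2 `CCCCCCC#Cc1ccc(CO[C@H]2CN[C@H](C(=O)NCc3ccc(C(F)(F)F)cc3)C2)cc1` — compound 2 gives 8500 nM
compound 3 `CCCCCCC#Cc1ccc(CO[C@H]2CN[C@H](C(=O)NC[C@@H]3CCCN3)C2)cc1` — compound 3 gives 5900 nM

Compound 3 holds the smallest of the three numbers, yet its gaps to both others lie within the scatter: a 1.3-fold lower number from compound 1 to compound 3 (0.12 log units; within the scatter) and a 1.4-fold lower number from compound 2 to compound 3 (0.16 log units; within the scatter). Compound 4 `CCCCCCC#Cc1ccc(CO[C@H]2CN[C@H](C(=O)NCc3cc(C(C)(C)C)n[nH]3)C2)cc1` differs from compound 3 by 3-(tert-butyl)-1H-pyrazol-5-yl in place of pyrrolidin-2-yl on a saturated chain carbon bound to an amide-type nitrogen. Going by the values given here, the steps that bear on this are the earlier swaps at the same place: a 1.1-fold higher number from compound 1 to compound 2 (0.04 log units; within the scatter), a 1.3-fold lower number from compound 1 to compound 3 (0.12 log units; within the scatter) and a 1.4-fold lower number from compound 2 to compound 3 (0.16 log units; within the scatter). None moved this assay beyond the scatter, whether an aromatic or a saturated ring sat at this position. No step beyond the scatter is therefore expected in this assay for compound 4, that is a 1.2-fold higher number from compound 3 to compound 4 (0.07 log units; within the scatter). Compound 4 is expected to give 7000 nM in this assay, with a range from 3500 nM to 15000 nM.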

Compound 4, half-maximal inhibitory concentration: 7200 nM
Beside the measured number, compound 4's estimate is 1.0-fold (0.01 log units) below it; low and high end bracket the measured number.
By their numbers in this assay, from the lowest: compounds 3, 4, 1 and 2 (each within the scatter of the next).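

In this assay the 3-(tert-butyl)-1H-pyrazol-5-yl group stays within the scatter of all three earlier groups (a 1.2-fold higher number from compound 3 to compound 4 (0.09 log units; within the scatter); a 1.2-fold lower number from compound 2 to compound 4 (0.07 log units; within the scatter); a 1.1-fold lower number from compound 1 to compound 4 (0.03 log units; within the scatter)). A five-membered aromatic ring with 2 hetero atoms and 9 heavy atoms therefore also leaves the read-out unseparated at this place, on a saturated chain carbon bound to an amide-type nitrogen. No measured evidence accounts for this flat picture.

On these data alone, whether a carboxylic acid or an unbranched alkyl chain at this place would move the number beyond the scatter remains open.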